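A Single Hydroxy Group on the Acetamido Side Chain

This account rests on a few compounds, and the source may have more. Where it says the series, first, only, none or still open, it means among the compounds named here.

In a functional assay on HCT-8 cells (Homo sapiens) for antiproliferative activity, read by MTT assay, with a stated time of 48 h (a lower number here means a stronger inhibitor, a higher number a weaker inhibitor), compound 1 (`CCNCC(=O)Nc1cc(OC)ccc1C(=O)c1ccc2c(c1)C=CC(C)(C)O2`) gives 3990 nM while compound 2 (`C=C(c1cc(OC)c(OC)c(OC)c1)c1ccc(OC)c(O)c1NC(C)=O`) gives 340 nM and so holds the lower of the two numbers, with a gap beyond the usual scatter of repeat measurements. Compound 3 (`C=C(c1cc(OC)c(OC)c(OC)c1)c1ccc(OC)c(O)c1NC(=O)CO`) differs from compound 2 by one small edit: hydroxy in place of hydrogen on a saturated chain carbon bound to a carbonyl carbon. The acetamido group thereby becomes ((hydroxymethyl)carbonyl)amino. Going by the values given here, no measured pair here shows what such an edit does, so any forecast is loose. The expectation in this assay is no change beyond the scatter, with a 1.1-fold lower number from compound 2 to compound 3 (0.05 log units; within the scatter) as the estimated step. For compound 3 the estimated value is 300 nM with an expected range of 70 nM to 1300 nM in repeat measurements.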

Compound 3, half-maximal inhibitory concentration: 40 nM
Compound 3: middle estimate off by 7.5-fold (0.88 log units), on the high side, outside the stated range (below it).
By their numbers in this assay, from the lowest: compound 3; then compound 2; then compound 1.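

Going by these compounds alone, compound 2 and compound 3 differ in one place, which gives the first direct reading of this position: hydroxy in place of hydrogen on a saturated chain carbon bound to a carbonyl carbon gives an 8.5-fold lower number from compound 2 to compound 3 (0.93 log units; beyond the scatter) in this assay and lies beyond the usual scatter. The side chain is therefore not a silent spot, as turning acetamido into ((hydroxymethyl)carbonyl)amino adds only one heavy atom, an oxygen, yet clearly moves the number. Nothing measured here accounts for why the number falls.

From the compounds shown here alone, it remains open whether the hydroxy itself matters or whether other groups on that carbon would give a similar step, such as a methoxy, an amine or a longer hydroxyethyl chain. A single pair also cannot show whether the same edit would give a similar step on a different core.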